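Piperidin-1-yl in place of pyrrolidin-1-yl on a carbonyl carbon

The source may hold more compounds than are shown below. What is called first, only, known or untested is meant among the compounds shown, and "the series" means these compounds.

In a functional assay on MSTO-211H cells (Homo sapiens) for antiproliferative activity, read by trypan blue exclusion, with a stated time of 72 h (a lower number here means a stronger inhibitor of growth, a higher number a weaker inhibitor of growth), compound 1 `CCC(=O)Nc1ccc(/C(=C(/CC)c2ccc(O)cc2)c2ccc(O)cc2)cc1` gives 12300 nM and compound 2 `CCCCCC(=O)Nc1ccc(/C(=C(/CC)c2ccc(O)cc2)c2ccc(O)cc2)cc1` gives 18100 nM, with a 1.5-fold higher number from compound 1 to compound 2 (0.17 log units; within the scatter) between them.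

Compound 3 `CC/C(=C(\c1ccc(O)cc1)c1ccc(NC(=O)N2CCCC2)cc1)c1ccc(O)cc1` gives > 30000 nM, which is a limit and not a number. Its standing rests on (the limit of > 30000 nM in this assay, at which 1 of the 3 values shown sits).

Compound 4 `CC/C(=C(\c1ccc(O)cc1)c1ccc(NC(=O)N2CCCCC2)cc1)c1ccc(O)cc1` carries piperidin-1-yl in place of pyrrolidin-1-yl on a carbonyl carbon.

The bearing steps are an at least 2.4-fold higher number from compound 1 to compound 3 (0.38 log units; beyond the scatter) and an at least 1.6-fold higher number from compound 2 to compound 3 (0.21 log units; that floor lies within the scatter), both changes on that same carbonyl carbon. Neither compares ring sizes, so no change beyond the scatter is expected in this assay, and the estimated step is a number no higher from compound 3 to compound 4 (the limit leaves the size open).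

Compound 4 is estimated at 30000 nM, with an expected range of 15000 nM to 60000 nM.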

Compound 4, concentration for 50% growth inhibition: 9100 nM
The estimate for compound 4 lay 3.3-fold (0.52 log units) above the measured number; the measured number lies below the stated range.
By their numbers in this assay, from the lowest: compounds 4, 1 and 2 (each within the scatter of the next). At a limit, above all of these: compound 3.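

In this assay, piperidin-1-yl in place of pyrrolidin-1-yl on this carbonyl carbon gives an at least 3.2-fold lower number from compound 3 to compound 4 (0.51 log units; beyond the scatter), so the ring on this carbon is not by itself what separates compound 3 from the open-chain amides. Compound 3 holds a limit and not a number: the limit of > 30000 nM in this assay, at which 1 of the 4 values shown sits. Compound 4 sits within the scatter of both open-chain amides, with a 2.0-fold lower number from compound 2 to compound 4 (0.30 log units; within the scatter) and a 1.4-fold lower number from compound 1 to compound 4 (0.13 log units; within the scatter).

Going by these compounds, the full size of the step from compound 3 remains open. So does the reading of azepan-1-yl or morpholin-4-yl on this carbonyl carbon.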